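The compounds below may be only part of what the source reports. "The series", "measured", "known", "first", "only" and "open" are said of these compounds alone.

In an assay on isolated protein for inhibition of thyroid peroxidase (Homo sapiens) (on this read-out higher numbers stand for weaker inhibition and lower numbers for stronger inhibition), compound 1 `NCCCCn1cc(-c2ccc3cc[nH]c3c2)c(C(F)(F)F)n1` gives only a limit, > 30000 nM. Compound 2 `NC(=O)Cn1cc(-c2ccc3cc[nH]c3c2)c(C(F)(F)F)n1` likewise gives only a limit in this assay, > 30000 nM. The step that the two limits leave unreadable from compound 1 to compound 2 is therefore of unknown size, and compound 2 stands at the point where both values shown sit, as the limit of > 30000 nM in this assay, at which 2 of the 2 values shown sit, records. Compound 3 `NC[C@H]1C[C@H](n2cc(-c3ccc4cc[nH]c4c3)c(C(F)(F)F)n2)C1` differs from compound 2 by a group of 6 heavy atoms (5 carbon, 1 nitrogen; one four-membered non-aromatic ring of carbon only) in place of a group of 4 heavy atoms (2 carbon, 1 nitrogen, 1 oxygen; no ring), on an aromatic nitrogen. Among the measured compounds shown here, no measured step bears on this change, and the two limits give neither size nor direction for it. Compound 3 is expected to give about 30000 nM, between 5000 nM and 100000 nM, which means an estimated step of a number no higher from compound 2 to compound 3 (the limit leaves the size open).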

Compound 3, half-maximal inhibitory concentration: > 30000 nM
Compound 3 ended at the assay's limit; the forecaster's own chance of this, stated with the estimate: 75%; the middle value lies on the limit itself.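

Compound 3 gives only a limit, like compound 1 and compound 2, so no step among the three can be read: the limit of > 30000 nM in this assay, at which 3 of the 3 values shown sit.

The compounds shown leave open how strongly any of them acts in this assay, and whether the group on the aromatic nitrogen matters at all.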